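The compounds below may be only part of what the source reports. "The series", "measured", "known", "first", "only" and "open" are said of these compounds alone.

Within the data shown here, in an assay for inhibition of Fatty-acid amide hydrolase 1 (Rattus norvegicus) (on this read-out higher numbers stand for weaker inhibition and lower numbers for stronger inhibition), compound 3 `N#Cc1cnc(C(=O)CCc2ccc(Oc3ccccc3)cc2)o1` gives 0.8 nM, the lowest of the three numbers measured so far. Compound 2 `COC(=O)c1cc(-c2cnc(C(=O)CCc3ccc(-c4ccccc4)cc3)o2)ccn1` gives 1.5 nM, which lies within the scatter of the value for compound 3. Compound 1 `CN(C)C(=O)c1cnc(C(=O)CCc2ccc(Oc3ccccc3)cc2)o1` gives 5.4 nM, and the step of a 6.8-fold lower number from compound 1 to compound 3 (0.83 log units; beyond the scatter) lies beyond the scatter. Compound 4 `O=C(CCc1ccc(Oc2ccccc2)cc1)c1ncc(C(F)(F)F)o1` differs from compound 3 in one place: trifluoromethyl in place of cyano on an aromatic carbon. Among the measured compounds shown here, no measured step exchanges a nitrile for a trifluoromethyl group; the only step that touches the same group is a 6.8-fold lower number from compound 1 to compound 3 (0.83 log units; beyond the scatter), which shows that changing this group can move this assay by a modest amount. For the measured compounds named here, with no direct precedent, the expected step of a 3.1-fold higher number from compound 3 to compound 4 (0.49 log units; beyond the scatter) is a small one, if any, more likely toward a higher number since compound 3 with the nitrile gives 0.8 nM, the lowest number seen. Compound 4 is therefore estimated at 2.5 nM in this assay, with a range from 0.6 nM to 10 nM.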

Compound 4, inhibition constant: 2 nM
The estimate for compound 4 lay 1.3-fold (0.10 log units) above the measured number; low and high end bracket the measured number.
By their numbers in this assay, from the lowest: compounds 3, 2 and 4 (each within the scatter of the next, the first and the last beyond it); then compound 1.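

In this assay, among these compounds, exchanging the cyano group for trifluoromethyl gives a 2.5-fold higher number from compound 3 to compound 4 (0.40 log units; beyond the scatter), the first direct evidence on this change at the carbon next to the ring oxygen. Trifluoromethyl in place of dimethylcarbamoyl gives a 2.7-fold lower number from compound 1 to compound 4 (0.43 log units; beyond the scatter), so the three groups at this carbon now fall in a clear order, with cyano giving the lowest number, trifluoromethyl the middle one and dimethylcarbamoyl the highest, each step lying beyond the scatter. Nothing available explains this order.

The compounds shown leave open where a carboxylic acid, a primary amine or a simple methyl group at this carbon would fall in that order. They also leave open whether the same order would hold with the rest of the molecule changed, for instance with a longer chain before the phenoxyphenyl group.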